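Cyclopentyloxy in place of fluoro on the aryl sulfonamide

The source may report more compounds than this note shows. Statements on the series, on what has been measured and on what is new or still open speak of the compounds shown alone.

Compound 2 `O=S(=O)(c1ccc(F)c(F)c1)N1CCCC(Cn2ccnc2)C1` gives 43 nM in an assay on isolated protein for inhibition of Aromatase (Homo sapiens), read by fluorescence; on this read-out higher numbers stand for weaker inhibition and lower numbers for stronger inhibition. Among the three measured compounds it holds the second highest number: compound 3 `O=S(=O)(c1ccc(F)cc1)N1CCCC(Cn2ccnc2)C1` gives 51 nM in this assay, and the gap of a 1.2-fold higher number from compound 2 to compound 3 (0.07 log units; within the scatter) leaves the two indistinguishable. Among the measured compounds shown here, compound 1 `COc1ccc(S(=O)(=O)N2CCCC(Cn3ccnc3)C2)cc1F` gives 14 nM in this assay, and the shift of a 3.1-fold higher number from compound 1 to compound 2 (0.49 log units; beyond the scatter) is the only change in the set that clearly exceeds the scatter.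

Compound 4 `O=S(=O)(c1ccc(OC2CCCC2)c(F)c1)N1CCCC(Cn2ccnc2)C1` differs from compound 2 by cyclopentyloxy in place of fluoro on an aromatic carbon. For the measured compounds named here, the one measured step that bears on this change is the alkoxy-to-fluoro swap at the same carbon, a 3.1-fold higher number from compound 1 to compound 2 (0.49 log units; beyond the scatter); the hydrogen-for-fluoro swap, a 1.2-fold higher number from compound 2 to compound 3 (0.07 log units; within the scatter), concerned a different carbon and stayed within the scatter. Restoring an alkoxy group is therefore expected to lower the number in this assay, although the entering group is much larger than the methoxy of compound 1, so the size is uncertain. Compound 4 is expected to show a 2.9-fold lower number from compound 2 to compound 4 (0.46 log units; beyond the scatter), giving an estimate of 15 nM with a range from 5 nM to 60 nM.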

Compound 4, half-maximal inhibitory concentration: 22 nM
The estimate for compound 4 lay 1.5-fold (0.17 log units) below the measured number; measured number inside the range.
By their numbers in this assay, from the lowest: compounds 1, 4, 2 and 3 (each within the scatter of the next, the first and the last beyond it).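

The carbon para to a large group, ortho to the fluoro group, accepts a far bulkier substituent than the earlier compounds had shown: in this assay, cyclopentyloxy replaces fluoro with no change beyond the scatter (a 2.0-fold lower number from compound 2 to compound 4 (0.29 log units; within the scatter)). Replacing the methyl on the oxygen with cyclopentyl also stays within the scatter (a 1.6-fold higher number from compound 1 to compound 4 (0.20 log units; within the scatter)), so the alkyl group on this oxygen can grow from methyl to a five-membered ring without a clear penalty, yet compound 4 cannot be assigned to the level of either compound 1 or compound 2. No measurement offered here explains this tolerance.

The compounds shown leave open whether the oxygen itself matters, which a cyclopentylamino group or a directly attached cyclopentyl at this carbon would address. They also leave open how far the group can grow, as with a cyclohexyloxy group or a longer chain such as hexyloxy.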